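Swapping the Sulfonyl Aryl Group: an Expected Clearance Shift

The compounds below may be only part of what the source reports. "The series", "measured", "known", "first", "only" and "open" are said of these compounds alone.

Measured so far:
Compound 1 `O=S(=O)(c1ccc(F)c(Cl)c1)c1cnc2c(F)cccc2c1-c1cccc(Cl)c1`; in an ADME assay on microsomes from liver (Homo sapiens) for metabolic stability, tested at 2.5 uM (a lower number here means slower removal, a higher number faster removal of the compound), compound 1 gives 0.18 mL/min.
Compound 2 `N#Cc1cccc(S(=O)(=O)c2cnc3c(F)cccc3c2-c2cccc(Cl)c2)c1`; in this assay compound 2 gives 1.11 mL/min.
Compound 3 `O=S(=O)(c1ccc(F)c(Cl)c1)c1cnc2cc(F)ccc2c1-c1cccc(F)c1`; in this assay compound 3 gives 0.25 mL/min.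

Compound 4 `N#Cc1cccc(S(=O)(=O)c2cnc3cc(F)ccc3c2-c2cccc(F)c2)c1` has not been measured. It differs from compound 3 by 3-cyanophenyl in place of 3-chloro-4-fluorophenyl on a sulfonyl sulfur. The same change already appears once, from compound 1 to compound 2, as 3-cyanophenyl in place of 3-chloro-4-fluorophenyl on a sulfonyl sulfur, where the number moved a 6.2-fold higher number from compound 1 to compound 2 (0.79 log units; beyond the scatter). The place of the change is identical in both pairs, so it is the same change. The difference between the cores of compound 1 and compound 3 is not broken down here; their values in this assay lie within the scatter of each other.

For compound 4 a step of a 5.6-fold higher number from compound 3 to compound 4 (0.75 log units; beyond the scatter) is expected, set beside the earlier step because that pair moved a 6.2-fold higher number from compound 1 to compound 2 (0.79 log units; beyond the scatter). Compound 4 is therefore estimated at 1.4 mL/min, with a likely range from 0.6 mL/min to 3.5 mL/min.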

Compound 4, intrinsic clearance in a liver preparation (reported as CLH), per the amount of preparation that the assay uses: 0.78 mL/min
Beside the measured number, compound 4's estimate is 1.8-fold (0.25 log units) above it; the measured number falls inside the stated range.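

In this assay, putting 3-cyanophenyl in place of 3-chloro-4-fluorophenyl on the sulfonyl sulfur again gives faster removal, with a 3.1-fold higher number from compound 3 to compound 4 (0.49 log units; beyond the scatter). The step points the same way on both cores, and its size cannot be told apart between them: the same change on two cores in this assay, a 6.2-fold higher number (0.79 log units; beyond the scatter) from compound 1 to compound 2 and a 3.1-fold higher number (0.49 log units; beyond the scatter) from compound 3 to compound 4, 2.0-fold (0.30 log units) apart, within the scatter of two such steps. This shows the change carrying over between these two cores only; two pairs cannot show that it holds across the whole series, and they do not explain why removal speeds up.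

The compounds shown carry only these two groups on the sulfonyl sulfur, so the effect of an amine or an alkyl chain there remains open. Whether the step would persist on a core bearing a carboxylic acid is also unknown.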